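Methoxy for methyl on the benzyl ring

This account rests on a few compounds, and the source may have more. Where it says the series, first, only, none or still open, it means among the compounds named here.

Compound 1 `NC(=O)N1CCN(C(=S)SCc2cn(Cc3ccccc3F)nn2)CC1` gives 11300 nM in a functional assay on MGC-803 cells (Homo sapiens) for cytotoxicity, read by MTT assay, with a stated time of 72 h; a lower number here means a stronger inhibitor, a higher number a weaker inhibitor.
Compound 2 `NC(=O)N1CCN(C(=S)SCc2cn(Cc3ccc(Cl)cc3)nn2)CC1` reaches only the limit > 128000 nM in this assay, a limit rather than a number.
Compound 3 `Cc1ccc(Cn2cc(CSC(=S)N3CCN(C(N)=O)CC3)nn2)cc1` gives 29900 nM in this assay.

Compound 3 holds the highest of the two numbered values; the nearest value differs by a 2.6-fold higher number from compound 1 to compound 3 (0.42 log units; beyond the scatter), and the remaining entry is a limit (the limit of > 128000 nM in this assay, at which 1 of the 3 values shown sits). Compound 4 `COc1ccc(Cn2cc(CSC(=S)N3CCN(C(N)=O)CC3)nn2)cc1` differs from compound 3 by methoxy in place of methyl on an aromatic carbon. For the measured compounds named here, no measured step changes methyl to methoxy. The nearest comparisons are an at least 4.2-fold lower number from compound 2 to compound 3 (0.63 log units; beyond the scatter) and an at least 11-fold higher number from compound 1 to compound 2 (1.05 log units; beyond the scatter), both showing that the benzyl substituent can shift the number strongly, but both involve chloro, so they bear only loosely. The step from compound 3 to compound 4 is expected to be a 1.1-fold higher number from compound 3 to compound 4 (0.03 log units; within the scatter), small or within the scatter. Compound 4 is therefore estimated at 32000 nM, between 10000 nM and 110000 nM.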

Compound 4, half-maximal inhibitory concentration: > 128000 nM
Compound 4: only a limit was reported; the forecaster's own chance of this, stated with the estimate: 15%; middle value at least 4.0-fold (0.60 log units) away from the limit.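

In this assay, the group on this benzyl carbon is not interchangeable even between methyl and methoxy: an at least 4.2-fold higher number from compound 3 to compound 4 (0.63 log units; beyond the scatter). The methoxy compound also separates clearly from the 2-fluorophenyl compound: an at least 11-fold higher number from compound 1 to compound 4 (1.05 log units; beyond the scatter). Compound 2 and compound 4 both rest on a limit, not a number, and the step between them cannot be read: the limit of > 128000 nM in this assay, at which 2 of the 4 values shown sit.

Going by these compounds, whether chloro and methoxy truly match therefore stays open. Also open, on these data alone, is whether an amine or a carboxylic acid in this place would give a number at all, or a lower one than compound 3.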